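Compound 2 to compound 4: replacing a carbonyl substituent

This account rests on a few compounds, and the source may have more. Where it says the series, first, only, none or still open, it means among the compounds named here.

Compound 1 `CCn1c(C(=O)N(CCC#N)CCC#N)ccc1C(CC)(CC)c1ccc(OCCC(O)(CC)CC)c(C)c1`: > 50000 nM, a limit of the assay
Compound 2 `C#CC(C)OC(=O)c1ccc(C(CC)(CC)c2ccc(OCCC(O)(CC)CC)c(C)c2)n1CC`: > 50000 nM, a limit of the assay
Compound 3 `CCOC(=O)CN(C)C(=O)c1ccc(C(CC)(CC)c2ccc(OCCC(O)(CC)CC)c(C)c2)n1CC`: 3210 nM

All three values come from a functional assay on MCF7 cells (Homo sapiens) for antiproliferative activity, read by MTT assay, with a stated time of 48 h; on this read-out lower numbers stand for stronger inhibition and higher numbers for weaker inhibition. Compound 2 gives no number, only the limit > 50000 nM. This places it at the limit of > 50000 nM in this assay, at which 2 of the 3 values shown sit. The other limit belongs to compound 1, and between the two there is a step that the two limits leave unreadable from compound 1 to compound 2.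

The change leading to compound 4 `CCOC(=O)C(CC(=O)OC)NC(=O)c1ccc(C(CC)(CC)c2ccc(OCCC(O)(CC)CC)c(C)c2)n1CC` falls on the carbonyl carbon: a group of 12 heavy atoms (7 carbon, 1 nitrogen, 4 oxygen; no ring) in place of a group of 5 heavy atoms (4 carbon, 1 oxygen; no ring), on a carbonyl carbon. The closest guide is the large change an at least 15-fold lower number from compound 2 to compound 3 (1.19 log units; beyond the scatter), where ((ethoxycarbonyl)methyl)(methyl)amino enters on that same carbon. A nitrogen-bearing group there does not always give a measurable value, as the equally large an at least 15-fold lower number from compound 1 to compound 3 (1.19 log units; beyond the scatter) shows. Within the data shown here, the group entering compound 4 has an ethoxycarbonyl in common with the group of compound 3, although it is larger, so it is expected to behave more like that group than the one in compound 1. A large step toward stronger inhibition is therefore expected in this assay, estimated as an at least 8.3-fold lower number from compound 2 to compound 4 (0.92 log units; beyond the scatter). A result at the limit remains possible. For compound 4 the estimated value is 6000 nM, with an expected range from 1200 nM to 40000 nM.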

Compound 4, half-maximal inhibitory concentration: 390 nM
Estimate against measurement, compound 4: 15-fold (1.19 log units) above; measured number below the stated range.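

Among these compounds, on the carbonyl carbon, a measurable value is no longer tied to the single group of compound 3: this assay records an 8.2-fold lower number from compound 3 to compound 4 (0.92 log units; beyond the scatter), so a measured change in potency can now be read between two groups at this place. The wider gaps are an at least 120-fold lower number from compound 2 to compound 4 (2.10 log units; beyond the scatter) and an at least 120-fold lower number from compound 1 to compound 4 (2.10 log units; beyond the scatter), and these are only bounds because both start from a limit of the assay, not a number: the limit of > 50000 nM in this assay, at which 2 of the 4 values shown sit. Among the four compounds, the two groups holding an ethoxycarbonyl give numbers, whereas the (1-methylprop-2-yn-1-yl)oxy group of compound 2 and the nitrogen-bearing group of compound 1 do not, so a nitrogen on this carbon does not by itself give a measurable value.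

The compounds shown leave open which part of the group in compound 4 carries the gain, the ethoxycarbonyl or the methyl ester side chain. They also leave open whether a carboxylic acid in place of either ester, or a simple amine on the carbonyl carbon, would keep this level of inhibition.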